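The compounds below may be only part of what the source reports. "The series", "measured", "known", "first", "only" and "open" are said of these compounds alone.

Series notes. Compound 1 `N#Cc1ccccc1/C=N/Nc1nc(N)c2ncn([C@@H]3O[C@H](CO)[C@@H](O)[C@H]3O)c2n1` gives 2.9 nM in an assay on CHO-K1 cells for displacement of a labelled ligand from adenosine receptor A1 (Homo sapiens), read by scintillation counting, with a stated time of 60 min; on this read-out lower numbers stand for stronger inhibition and higher numbers for weaker inhibition. Compound 3 `Nc1nc(N/N=C/C2CCCC2)nc2c1ncn2[C@@H]1O[C@H](CO)[C@@H](O)[C@H]1O` gives 5.6 nM in this assay. For compound 2 `CCCOc1ccc(/C=N/Nc2nc(N)c3ncn([C@@H]4O[C@H](CO)[C@@H](O)[C@H]4O)c3n2)cc1` this assay reports only a limit, > 10000 nM. Compound 3 therefore stands at the highest of the two numbers that are not limits, with compound 1 nearest: the step of a 1.9-fold higher number from compound 1 to compound 3 (0.29 log units; within the scatter) lies within the scatter. Against that, the step of an at least 1700-fold lower number from compound 2 to compound 3 (3.25 log units; beyond the scatter) is large, as is an at least 3400-fold higher number from compound 1 to compound 2 (3.53 log units; beyond the scatter), and the limit of > 10000 nM in this assay, at which 1 of the 3 values shown sits, marks where the value of compound 2 sits.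

Compound 4 `CN(C)c1ccc(/C=N/Nc2nc(N)c3ncn([C@@H]4O[C@H](CO)[C@@H](O)[C@H]4O)c3n2)cc1` differs from compound 3 by 4-(dimethylamino)phenyl in place of cyclopentyl on a carbon with a double bond to nitrogen. Of the measured steps, an at least 1700-fold lower number from compound 2 to compound 3 (3.25 log units; beyond the scatter) bears most directly, since it also exchanges cyclopentyl for a substituted six-membered aromatic ring of carbon only; the step of a 1.9-fold higher number from compound 1 to compound 3 (0.29 log units; within the scatter) shows that another aromatic ring, 2-cyanophenyl, costs nothing beyond the scatter. The 4-(dimethylamino)phenyl case is closer in shape to 4-propoxyphenyl, so a large rise in the number is expected, a 450-fold higher number from compound 3 to compound 4 (2.65 log units; beyond the scatter). Compound 4 is thus estimated at 2500 nM, within 200 nM to 30000 nM, with a real chance that only a limit is reported.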

Compound 4, inhibition constant: > 10000 nM
Compound 4: only a limit was reported (the forecaster's own chance of this, stated with the estimate: 35%); at least 4.0-fold (0.60 log units) between middle value and limit.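

In this assay, the large loss seen with 4-propoxyphenyl is not confined to that group: 4-(dimethylamino)phenyl on the same carbon gives an at least 1700-fold higher number from compound 3 to compound 4 (3.25 log units; beyond the scatter), and against the aromatic 2-cyanophenyl it gives an at least 3400-fold higher number from compound 1 to compound 4 (3.53 log units; beyond the scatter). The second step shows that the outcome differs sharply between aromatic groups at this place, with compound 1 going against any rule that an aromatic ring here is lost. Compound 2 and compound 4 both end in a limit, their step cannot be read, and the two groups cannot be ranked: the limit of > 10000 nM in this assay, at which 2 of the 4 values shown sit.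

The compounds shown leave open whether the loss follows the 4-substituted phenyl pattern or the particular groups carried. Unsubstituted phenyl and 4-cyanophenyl at this place would test that directly.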